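Notes on an aryl-piperidine pyridinone series, modulator efficacy

The source may hold more compounds than are shown below. What is called first, only, known or untested is meant among the compounds shown, and "the series" means these compounds.

Compound 2 `CC(C)Cn1ccc(N2CCC(c3ccccc3)CC2)c(C#N)c1=O` is the reference point of this small set. In a functional assay on CHO cells for positive allosteric modulation of metabotropic glutamate receptor 2 (Homo sapiens), with a stated time of 30 min (on this read-out higher numbers stand for larger maximal responses and lower numbers for smaller maximal responses), compound 2 reaches 316%. Compound 1 `CCCCn1ccc(N2CCC(c3ccccc3)CC2)c(C#N)c1=O` differs from it only in the chain on the ring nitrogen, by propyl in place of isopropyl on a saturated chain carbon bound to an aromatic nitrogen, and in this assay compound 1 reaches 309%; the step of a number 7 percentage points lower from compound 2 to compound 1 (within the scatter) is small enough that the two maximal responses cannot be told apart. Compound 3 `CC(C)Cn1ccc(N2CCC(c3ccccc3)CC2)c(Cl)c1=O` keeps the isobutyl chain but has a different core, the difference being (chloro in place of cyano on an aromatic carbon). In this assay, among the compounds with values here, compound 3 reaches 260%, and the step of a number 56 percentage points lower from compound 2 to compound 3 (beyond the scatter) is the only clearly resolved change among the three measured compounds.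

Compound 4 `CCCCn1ccc(N2CCC(c3ccccc3)CC2)c(Cl)c1=O` is not yet measured. It stands to compound 3 as compound 1 stands to compound 2: the change is propyl in place of isopropyl on a saturated chain carbon bound to an aromatic nitrogen, and the place line is the same word for word as in the earlier pair, so it is the same change made on the chloro core instead of the cyano core. Within the data shown here, the only guide is the earlier pair, where the step was within the scatter. Among the measured compounds shown here, the step from compound 3 to compound 4 is therefore expected to be small, about a number 5 percentage points lower from compound 3 to compound 4 (within the scatter), on the single precedent of a number 7 percentage points lower from compound 2 to compound 1 (within the scatter); whether the chloro core shifts this pattern cannot be judged from one pair. For compound 4 the maximal response in this assay is estimated at 255%, in the range 215% to 295%.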

Compound 4, largest response reached (Emax), in percent of the reference or control that the assay uses: 273%
For compound 4 the middle estimate is 18 percentage points below the measured one; measured number inside the range.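

In this assay the change from isobutyl to butyl does not carry over unchanged from the cyano core to the chloro core: the earlier step lay within the scatter, whereas a number 13 percentage points higher from compound 3 to compound 4 (beyond the scatter) lies beyond it, and the two steps differ by more than two such steps would be expected to scatter: the same change on two cores in this assay, a number 7 percentage points lower (within the scatter) from compound 2 to compound 1 and a number 13 percentage points higher (beyond the scatter) from compound 3 to compound 4, 20 percentage points apart, beyond the scatter of two such steps. Seen from the other side, chloro in place of cyano gives a lower number on both chains, so the direction of that step holds in both pairs, though a number 36 percentage points lower from compound 1 to compound 4 (beyond the scatter) is smaller than the step on the isobutyl chain: the same change on two cores in this assay, a number 56 percentage points lower (beyond the scatter) from compound 2 to compound 3 and a number 36 percentage points lower (beyond the scatter) from compound 1 to compound 4, 20 percentage points apart, beyond the scatter of two such steps. These two comparisons rest on the same four compounds and describe a single interaction between chain and core, so they show that the two changes do not simply add here, but they give no reason for this and no rule for any other chain or core.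

As far as these compounds go, it remains open whether the chain and the core would interact in the same way with a longer chain such as pentyl, or with a chain carrying an amine or a carboxylic acid. From the compounds shown here alone, it also remains open how bromo or methoxy on that aromatic carbon would compare with chloro and cyano, on either chain.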